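The source may hold more compounds than are shown below. What is called first, only, known or untested is meant among the compounds shown, and "the series" means these compounds.

Compound 1 `Cc1ccc(C(=O)N2CCN(c3nc(=O)c4cc(C(F)(F)F)cc([N+](=O)[O-])c4s3)CC2)cc1` was tested in an ADME assay on Vero cells (Chlorocebus sabaeus) for cytotoxicity, read by MTT assay, with a stated time of 72 h; on this read-out lower numbers stand for higher toxicity in this test and higher numbers for lower toxicity in this test. In this assay compound 1 gives > 125000 nM, which is a limit of the assay and not a number, so on the numbers shown compound 1 stands only at a limit. Compound 2 `O=C(c1cccc(F)c1)N1CCN(c2nc(=O)c3cc(C(F)(F)F)cc([N+](=O)[O-])c3s2)CC1` differs from compound 1 by a 3-fluorophenyl in place of a 4-methylphenyl on a carbonyl carbon. In this assay compound 2 gives > 125000 nM, again a limit. The step that the two limits leave unreadable from compound 1 to compound 2 thus has no readable size. Compound 3 `O=C(C1CCC1)N1CCN(c2nc(=O)c3cc(C(F)(F)F)cc([N+](=O)[O-])c3s2)CC1` is not yet measured; it differs from compound 1 by cyclobutyl in place of 4-methylphenyl on a carbonyl carbon. Among the measured compounds shown here, the only measured step bears on it just in that both of its ends sit at the same limit, as the limit of > 125000 nM in this assay, at which 2 of the 2 values shown sit, records; no size can be read from it, and no step beyond the scatter is expected in this assay in either direction. Compound 3 is therefore expected to give about 150000 nM in this assay, between 60000 nM and 400000 nM. The step that the limit leaves unreadable from compound 1 to compound 3 so estimated is small, and a report of only a limit is the likeliest outcome.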

Compound 3, half-maximal cytotoxic concentration: > 125000 nM
Compound 3 ended at the assay's limit (the forecaster's own chance of this, stated with the estimate: 80%); the middle value is on the limit's open side.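

In this assay compound 3 gives > 125000 nM as a limit of the assay and not a number. Among the compounds shown here, no step among compound 1, compound 2 and compound 3 can be read, since all of them stand at one limit: the limit of > 125000 nM in this assay, at which 3 of the 3 values shown sit. The compounds shown leave open whether the groups on the carbonyl carbon make any difference in this assay at all.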